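A few compounds are considered here, and "the series" means these few. Any claim that something is new, unique, unknown or untested is made for them only; others in the source may bear on it.

Among the measured compounds shown here, compound 2 `COc1ccccc1NC(=O)Nc1nn(-c2ccccc2)c(=O)c2ccccc12` stands at the bottom of the three numbers so far in an assay on CHO cells for displacement of a labelled ligand from adenosine receptor A1 (Homo sapiens), tested at 10 uM; on this read-out lower numbers stand for less inhibition and higher numbers for more inhibition at the one concentration tested (going by the name of the read-out): compound 2 gives 0%. Its nearest neighbour is compound 1 `O=C(Nc1ccc(Cl)cc1)Nc1nn(-c2ccccc2)c(=O)c2ccccc12`, which in this assay gives 10%; the step of a number 10 percentage points lower from compound 1 to compound 2 (within the scatter) is within the scatter, so the two compounds are not separated on this read-out. The furthest is compound 3 `CC(=O)N(C(C)=O)c1nn(-c2ccccc2)c(=O)c2ccccc12`, which in this assay gives 47%, beyond the scatter above compound 2.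

Compound 4 `O=C(Nc1ccccc1Cl)Nc1nn(-c2ccccc2)c(=O)c2ccccc12` follows from compound 2 by chloro in place of methoxy on an aromatic carbon. For the measured compounds named here, the only measured step that bears on it is a number 10 percentage points lower from compound 1 to compound 2 (within the scatter), in which the aryl group on the amide-type nitrogen was changed without a move beyond the scatter. Going by the values given here, no measured pair shows a chloro in place of a methoxy on this ring, so the expectation rests on the two diaryl ureas alone. Both are low in this assay, and for compound 4 a step of a number 8 percentage points higher from compound 2 to compound 4 (within the scatter) is expected, with nothing beyond the scatter. Compound 4 is therefore estimated at 8% in this assay, in the range 0% to 25%.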

Compound 4, a percentage reported as inhibition, at one concentration (the size of the read-out at that concentration, not a potency): 0%
Compound 4: middle estimate off by 8 percentage points, on the high side; the range from low to high includes it.
By their numbers in this assay, from the lowest: compounds 2, 4 and 1 (each within the scatter of the next); then compound 3.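

In this assay, chloro in place of methoxy on an aromatic carbon, ortho to a large group, gives no change at the digits printed from compound 2 to compound 4 (within the scatter), so this change does not separate the two compounds. Keeping the chloro and changing its place, 2-chlorophenyl in place of 4-chlorophenyl gives a number 10 percentage points lower from compound 1 to compound 4 (within the scatter), so the diaryl ureas compared here also remain unseparated on this read-out. Nothing available explains these results.

The compounds shown leave open whether an amine, a carboxylic acid or a longer chain such as ethoxy, placed ortho to the same large group, would produce a step beyond the scatter. Also open, on these data alone, is whether an unsubstituted phenyl on the same amide-type nitrogen would read any differently from these aryl groups.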